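The source may hold more compounds than are shown below. What is called first, only, known or untested is meant among the compounds shown, and "the series" means these compounds.

Measured in a functional assay on MGC-803 cells (Homo sapiens) for inhibition, read by MTT assay, with a stated time of 72 h; on this read-out lower numbers stand for stronger inhibition and higher numbers for weaker inhibition:
- compound 1 `O=C(NCc1ccc(NC(=O)c2cc(-c3ccccc3)ccc2N2CCCC2)cc1)OCc1cccnc1`: 10500 nM
- compound 2 `O=C(NCc1ccc(NC(=O)c2cccc(F)c2N2CCCC2)cc1)OCc1cccnc1`: > 100000 nM (a limit)
- compound 3 `O=C(NCc1ccc(NC(=O)c2ccc(F)cc2N2CCCC2)cc1)OCc1cccnc1`: 52100 nM

Compound 1 holds the lowest number in the series, and the gap to compound 3, the nearest value, lies beyond the scatter. Compound 2 reads > 100000 nM, which is a limit of the assay and not a number. Going by the values given here, this makes compound 1 the only measured compound that carries the phenyl group, and the next question is what happens when that group is replaced.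

Compound 4 `COc1ccc(N2CCCC2)c(C(=O)Nc2ccc(CNC(=O)OCc3cccnc3)cc2)c1` is not yet measured. It differs from compound 1 by one change, methoxy in place of phenyl on an aromatic carbon. Among the compounds with values here, no measured pair isolates this change, so the expectation rests on indirect evidence. Compound 3 also lacks the phenyl group and gives 52100 nM, a higher number than compound 1 shows. In this assay, a move to a higher number, beyond the scatter, is therefore expected, and the estimated step is a 2.9-fold higher number from compound 1 to compound 4 (0.46 log units; beyond the scatter). For compound 4 the estimated value is 30000 nM, with an expected range of 10000 nM to 90000 nM.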

Compound 4, half-maximal inhibitory concentration: 85700 nM
Compound 4: the middle estimate sits 2.9-fold (0.46 log units) below what was measured, within the range that was stated.
By their numbers in this assay, from the lowest: compound 1; then compounds 3 and 4 (each within the scatter of the next). At a limit, above all of these: compound 2.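

In this assay, going by these compounds alone, replacing phenyl with methoxy on the aromatic carbon para to the pyrrolidin-1-yl group gives an 8.2-fold higher number from compound 1 to compound 4 (0.91 log units; beyond the scatter), the first step that isolates a single change at this position. Within the data shown here, the position therefore responds to the group it carries, and of the two groups compared there, phenyl goes with the lower number, a difference that the earlier compounds could only suggest indirectly. Among these compounds, compound 2 is a limit and enters no step: the limit of > 100000 nM in this assay, at which 1 of the 4 values shown sits.

This single pair cannot separate the contributions of the aromatic ring, the size of the group and the oxygen of methoxy, and no measured property is available to assign a cause to the step. Open questions are whether a methyl group, which has no ring and no oxygen, would track with methoxy, whether a pyridyl ring would retain the lower number seen with phenyl, and how a charged group such as an amine or a carboxylic acid would read at this position.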